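From compound 3 to the acetyl compound 4

The source may hold more compounds than are shown below. What is called first, only, known or untested is meant among the compounds shown, and "the series" means these compounds.

Compound 1 `CC#C[C@H]1CN(S(=O)(=O)c2ccc(N)nc2)CCN1c1ccc(C(O)(COC)C(F)(F)F)cc1`: 93 mL.min-1.g-1
Compound 2 `CC#C[C@H]1CN(S(=O)(=O)c2ccc(N)nc2)CCN1c1ccc(S(=O)(=O)NCC2CC2)cc1`: 213 mL.min-1.g-1
Compound 3 `CC#C[C@H]1CN(S(=O)(=O)c2ccc(N)nc2)CCN1c1ccc(S(C)(=N)=O)cc1`: < 14 mL.min-1.g-1 (a limit)

All three readings come from an ADME assay (liver) for metabolic stability, with Liver microsome (Rattus norvegicus) as the target, using microsomes and NADPH, with a stated time of 30 min (a higher number here means faster removal of the compound, a lower number slower removal), and share the core of compound 1. Compound 3 stands at the limit of < 14 mL.min-1.g-1 in this assay, at which 1 of the 3 values shown sits, and has no exact number. Compound 4 `CC#C[C@H]1CN(S(=O)(=O)c2ccc(N)nc2)CCN1c1ccc(C(C)=O)cc1` carries acetyl instead: a group of 3 heavy atoms (2 carbon, 1 oxygen; no ring) in place of a group of 4 heavy atoms (1 carbon, 1 nitrogen, 1 oxygen, 1 sulfur; no ring), on an aromatic carbon and the site is para to a large group. Among the compounds with values here, two measured steps bear on this, an at least 6.6-fold lower number from compound 1 to compound 3 (0.82 log units; beyond the scatter) and an at least 15-fold lower number from compound 2 to compound 3 (1.18 log units; beyond the scatter), with a 2.3-fold higher number from compound 1 to compound 2 (0.36 log units; beyond the scatter) showing that changes at this site can move the number. Both steps into compound 3 point down, so losing its group is expected to raise the number by a modest step. The expected step is estimated as an at least 3.2-fold higher number from compound 3 to compound 4 (0.50 log units; beyond the scatter) in this assay and is upward. For compound 4 the estimate is 45 mL.min-1.g-1 with an expected range from 15 mL.min-1.g-1 to 130 mL.min-1.g-1 as its bounds.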

Compound 4, intrinsic clearance in microsomes: 249 mL.min-1.g-1
Compound 4: middle estimate off by 5.5-fold (0.74 log units), on the low side, and the stated range ends below it.
By their numbers in this assay, from the lowest: compound 1; then compounds 2 and 4 (each within the scatter of the next). At a limit, below all of these: compound 3.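

Replacing the group para to a large group with acetyl gives an at least 17-fold higher number from compound 3 to compound 4 (1.25 log units; beyond the scatter) in this assay, so a small group at this position does not by itself bring a low reading. Acetyl and (cyclopropylmethyl)sulfamoyl read alike, a 1.2-fold higher number from compound 2 to compound 4 (0.07 log units; within the scatter), while the other comparison gives a 2.7-fold higher number from compound 1 to compound 4 (0.43 log units; beyond the scatter). The reading of compound 3 is a limit, not a number: the limit of < 14 mL.min-1.g-1 in this assay, at which 1 of the 4 values shown sits.

On these data alone, the exact number for compound 3 remains open. Also open, as far as these compounds go, is whether an amine, a nitrile or a carboxylic acid at this position would read near that limit or with the higher values.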